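Swapping a Chlorophenyl for Pyridyl on the Diaryl Carbon

The compounds below may be only part of what the source reports. "The series", "measured", "known", "first", "only" and "open" are said of these compounds alone.

Compound 1, `O=C(O)Cc1sc(C(c2ccccc2)c2ccc(Cl)cc2)nc1-c1ccc(Cl)cc1`: 45 nM
Compound 2, `O=C(O)Cc1sc(C(c2ccc(F)cc2)c2ccc(F)cc2)nc1-c1ccc(Cl)cc1`: 9.7 nM

Compound 1 has the higher of the two numbers measured in an in vitro assay on HEK385-7 cells for displacement of a labelled ligand from prostaglandin D2 receptor 2 (Homo sapiens); on this read-out lower numbers stand for stronger inhibition and higher numbers for weaker inhibition. Its nearest neighbour is compound 2, whose value in this assay is lower, and the gap between them lies beyond the usual scatter of repeated measurements. Among the compounds with values here, no step between two measured compounds differing in a single place is available, so the two values show only that the two compounds differ and not what any single change does.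

Compound 3, `O=C(O)Cc1sc(C(c2ccccc2)c2ccccn2)nc1-c1ccc(Cl)cc1`, has not yet been measured in this assay. It differs from compound 1 in one place: pyridin-2-yl in place of 4-chlorophenyl on a saturated chain carbon bound to two aromatic carbons. Nothing measured here isolates the effect of such a change.

Within the data shown here, with no single-point step to lean on, the expectation for compound 3 rests on the starting value of compound 1, 45 nM, and on a modest move towards a higher number, with a wide range admitted. The expected step from compound 1 to compound 3 is a 2.7-fold higher number from compound 1 to compound 3 (0.43 log units; beyond the scatter). Compound 3 is therefore estimated at 120 nM, within a range from 40 nM to 400 nM.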

Compound 3, half-maximal inhibitory concentration: 810 nM
Compound 3: middle estimate off by 6.8-fold (0.83 log units), on the low side, and the stated range ends below it.
By their numbers in this assay, from the lowest: compound 2; then compound 1; then compound 3.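

Replacing 4-chlorophenyl with pyridin-2-yl on a saturated chain carbon bound to two aromatic carbons gives, in this assay, an 18-fold higher number from compound 1 to compound 3 (1.26 log units; beyond the scatter), a large step and the only one here that isolates a single place. It shows that this position is sensitive to which six-membered aromatic ring it carries, with the shared core and the other phenyl ring on that carbon left unchanged, something the earlier pair of values could not show. No measurement shown here accounts for the size of this loss.

The step exchanges a ring of carbon only bearing chlorine for a ring containing nitrogen and no chlorine, so these compounds leave open whether the loss goes with the arrival of the ring nitrogen, the departure of the chlorine, or both together. Also open, going by these compounds, is how a methoxyphenyl or a cyanophenyl group would read in the same place, and whether pyridin-2-yl would cost as much in a compound with a different aryl partner on that carbon.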